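The source may hold more compounds than are shown below. What is called first, only, known or untested is meant among the compounds shown, and "the series" means these compounds.

Measured so far:
compound 1 `CN1C[C@H]2C=C(c3cccnc3)C[C@H](C2)C1` — 11%
compound 2 `C1=C(c2ccc(-c3ccccc3)nc2)CC2CNCC1C2` — 18%
compound 3 `COc1ccc(C2=CC3CC(C2)CN(C)C3)cn1` — 20%

In an in vitro functional assay on SH-EP1 cells for agonist activity at Neuronal acetylcholine receptor; alpha4/beta2 (Homo sapiens), read by FLIPR and calcium flux (on this read-out higher numbers stand for larger maximal responses and lower numbers for smaller maximal responses), compound 1 gives 11%, the lowest of the three numbers, but its gaps to compound 2 and to compound 3 both lie within the usual scatter, so no ordering among the three is supported. All three reach only a small fraction of the reference response.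

The next compound, compound 4 `C1=C(c2cccnc2)C[C@H]2CNC[C@@H]1C2`, differs from compound 1 in one place: hydrogen in place of methyl on an amine nitrogen in a ring. Within the data shown here, no measured pair shows this change, so its effect in this assay is unknown; compound 2, which carries a hydrogen on that nitrogen, gives 18%, within the scatter of compound 1.

For compound 4 a small rise in this assay is expected, a number 9 percentage points higher from compound 1 to compound 4 (within the scatter), not clearly beyond the scatter. The estimate for compound 4 is 20%, ranging from 8% to 40%.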

Compound 4, largest response reached (reported as percent of maximum), in percent of the reference or control that the assay uses: 129%
Estimate against measurement, compound 4: 109 percentage points below, and the stated range ends below it.
By their numbers in this assay, from the lowest: compounds 1, 2 and 3 (each within the scatter of the next); then compound 4.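

In this assay, hydrogen in place of methyl on an amine nitrogen in a ring gives a number 118 percentage points higher from compound 1 to compound 4 (beyond the scatter), a large step. Among these compounds, this is the first measured pair to isolate this change, and it shows that the substituent on this nitrogen can strongly alter the maximal response on the core of compound 1. Nothing available explains the size of this step.
From the compounds shown here alone, whether an ethyl group or a longer chain on this nitrogen would keep or lose the response remains open. A single pair also leaves open whether the same step holds on other cores in the series.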